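Variation on the carbonyl carbon of the shared core

This account rests on a few compounds, and the source may have more. Where it says the series, first, only, none or still open, it means among the compounds named here.

Of the compounds shown here, two have numbers so far. Compound 1 `CCOC(=O)C1=C(C)NC(C)=C(C(=O)OCC)C1c1ccc(OCC(=O)NNC(=O)c2ccccc2)cc1` gives in a functional assay on the whole organism (strain Wistar) for inhibition, with Rattus norvegicus as the target, read by paw edema, with stated times of 30 min and 0.5 h, at a dose of 20 mg/kg (a lower number here means less inhibition, a higher number more inhibition at the dose given (going by the name of the read-out)), a reading of 9.1%. Compound 2 `CCOC(=O)C1=C(C)NC(C)=C(C(=O)OCC)C1c1ccc(OCC(=O)NNC(=O)c2ccsc2Cl)cc1` gives in this assay a reading of 12.9%. Among the compounds with values here, the one measured step, a number 3.8 percentage points higher from compound 1 to compound 2 (within the scatter), exchanges phenyl for 2-chlorothiophen-3-yl on a carbonyl carbon and stays within the scatter. Of the two numbers, that of compound 2 is the larger, but the gap to compound 1 is within the scatter, so nothing can be read into it.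

Compound 3 `CCOC(=O)C1=C(C)NC(C)=C(C(=O)OCC)C1c1ccc(OCC(=O)NNC(=O)CCC(=O)O)cc1` is the next member. The change from compound 2 is 2-carboxyethyl in place of 2-chlorothiophen-3-yl on a carbonyl carbon. Within the data shown here, no measured pair carries this change; the only known step, a number 3.8 percentage points higher from compound 1 to compound 2 (within the scatter), swaps one aromatic group for another on the same carbonyl carbon and stayed within the scatter. It bears on compound 3 only as a sign that the readings have so far changed little with the group on that carbonyl carbon. The expectation for this assay is thus no step beyond the scatter, estimated as a number 1.9 percentage points lower from compound 2 to compound 3 (within the scatter). Compound 3 is expected to give 11%, in the range 3% to 22%.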

Compound 3, a percentage reported as inhibition, in the whole organism at one dose (the size of the read-out at that dose, not a potency): 34.9%
For compound 3 the middle estimate is 23.9 percentage points below the measured one; measured number above the stated range.
By their numbers in this assay, from the lowest: compounds 1 and 2 (each within the scatter of the next); then compound 3.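

In this assay the group on the carbonyl carbon, whose other neighbour is the amide-type nitrogen, does make a difference: the step from 2-chlorothiophen-3-yl to 2-carboxyethyl gives a number 22 percentage points higher from compound 2 to compound 3 (beyond the scatter) and the step from phenyl to 2-carboxyethyl gives a number 25.8 percentage points higher from compound 1 to compound 3 (beyond the scatter) in the same direction. Exchanging one aromatic group for the other had shown no change beyond the scatter, so the position responds to the open chain with its carboxylic acid and not to every exchange made there. The change from compound 2 removes the ring and brings in a hydrogen-bond donor in one move, and no measurement at hand accounts for the step.

From the compounds shown here alone, whether the loss of the ring or the presence of the carboxylic acid carries the step stays open, since compound 3 differs from compound 1 and compound 2 in both at once. A plain propyl chain, the methyl ester of the acid, an amine at the chain end or a longer chain ending in the carboxylic acid would separate these, and the reading at a single dose leaves the potency of the series open.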